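The source may report more compounds than this note shows. Statements on the series, on what has been measured and on what is new or still open speak of the compounds shown alone.

Compound 1, `CCOc1ccc2nc(Cl)c(/C=N/NC(=O)c3cc4cc([N+](=O)[O-])ccc4oc3=O)cc2c1`, and compound 2, `CCOc1ccc2nc(Cl)c(/C=N/NC(=O)c3cc4ccccc4oc3=O)cc2c1`, share one core and differ only where hydrogen in place of nitro on an aromatic carbon describes. Compound 3, `CCOc1ccc(NC(=O)c2cc3cc([N+](=O)[O-])ccc3oc2=O)cc1`, is built on a different core; the difference between the two cores is not broken down here. Compound 4, `CCOc1ccc(NC(=O)c2cc3ccccc3oc2=O)cc1`, has not yet been tested. It stands to compound 3 exactly as compound 2 stands to compound 1: hydrogen in place of nitro on an aromatic carbon. The two place lines match word for word, so this is the same change made on two cores.

In a functional assay on HepG2 cells (Homo sapiens) for antiproliferative activity, read by fluorescence and resazurin assay, with a stated time of 48 h (on this read-out higher numbers stand for weaker inhibition and lower numbers for stronger inhibition), compound 1 gives 18100 nM. Compound 2 gives 33100 nM in this assay, and the change between them made a step of a 1.8-fold higher number from compound 1 to compound 2 (0.26 log units; within the scatter), which is within the scatter of repeated measurements. Compound 3 gives 28300 nM in this assay; its value lies within the scatter of both compound 1 and compound 2, so no order among the three can be read from these numbers.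

Among the measured compounds shown here, the only guide for compound 4 is the one measured pair, and that step was small. The expectation is therefore that removing the nitro group from compound 3 will again move the number only a little, about a 1.6-fold higher number from compound 3 to compound 4 (0.20 log units; within the scatter), a step within the scatter, because the step of a 1.8-fold higher number from compound 1 to compound 2 (0.26 log units; within the scatter) was of that size. On that basis compound 4 is expected to give about 45000 nM in this assay, most likely between 20000 nM and 100000 nM.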

Compound 4, half-maximal inhibitory concentration: 10400 nM
The estimate for compound 4 lay 4.3-fold (0.64 log units) above the measured number; the whole stated range lies above it.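

In this assay, putting hydrogen in place of the nitro group on the core of compound 3 gave a 2.7-fold lower number from compound 3 to compound 4 (0.43 log units; beyond the scatter), a modest but readable gain in inhibition, whereas the same swap on the core of compound 1 gave a 1.8-fold higher number from compound 1 to compound 2 (0.26 log units; within the scatter), a step too small to read. Among the compounds shown here, the change therefore does not carry over unchanged from one core to the other, so the step measured on one core would have been a poor guide to the step on the other: the same change on two cores in this assay, a 1.8-fold higher number (0.26 log units; within the scatter) from compound 1 to compound 2 and a 2.7-fold lower number (0.43 log units; beyond the scatter) from compound 3 to compound 4, 5.0-fold (0.70 log units) apart, beyond the scatter of two such steps This does not show a true reversal of direction, as the step on the core of compound 1 cannot be told apart from no change, and with only one pair on each core it does not explain why the two steps differ or predict what the swap would do on a third core.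

As far as these compounds go, it remains open whether an amine or a carboxylic acid at the same place on the ring would also give steps that differ between the two cores. From the compounds shown here alone, it also remains open which part of the difference between the two cores decides the size of the step, and whether the same gap would appear in cells other than those tested here.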